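A few compounds are considered here, and "the series" means these few. Any claim that something is new, unique, unknown or untested is made for them only; others in the source may bear on it.

Measured so far in this series:

compound 2 `CCN(Cc1ccccc1)c1ccc(C(=O)N2CCc3ccc(OS(N)(=O)=O)cc3C2)cc1` — 66.9%
compound 1 `CN(C)CCN(CCN(C)C)c1ccc(C(=O)N2CCc3ccc(OS(N)(=O)=O)cc3C2)cc1` — 3.8%

Among the measured compounds shown here, in an assay on HEK293 cells for inhibition of Steryl-sulfatase (Homo sapiens), tested at 0.1 uM (a higher number here means a stronger effect of the compound at the concentration tested, a lower number a weaker effect), compound 2 gives 66.9%, the higher of the two numbers known. For the measured compounds named here, compound 1 gives 3.8%, and the only measured step, a number 63.1 percentage points higher from compound 1 to compound 2 (beyond the scatter), is a change at the aniline nitrogen that lies beyond the scatter.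

Compound 3 `CCN(Cc1cccc(Br)c1)c1ccc(C(=O)N2CCc3ccc(OS(N)(=O)=O)cc3C2)cc1` differs from compound 2 by bromo in place of hydrogen on an aromatic carbon. Going by the values given here, no measured step bears on this change: the one step known concerns benzyl(ethyl)amino in place of bis(2-(dimethylamino)ethyl)amino and says nothing about a bromo on the benzyl ring. The shared core and the benzyl(ethyl)amino part are kept, so the anchor is the value of compound 2 in this assay. Among the compounds with values here, with no step of this kind measured, a step no larger than the scatter is expected from compound 2 to compound 3, in either direction, a number 3.1 percentage points higher from compound 2 to compound 3 (within the scatter). Compound 3 is therefore estimated at 70% in this assay, with a range from 50% to 88%.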

Compound 3, a percentage reported as inhibition, at one concentration (the size of the read-out at that concentration, not a potency): 80.2%
For compound 3 the middle estimate is 10.2 percentage points below the measured one, within the range that was stated.
By their numbers in this assay, from the lowest: compound 1; then compound 2; then compound 3.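

In this assay, the benzyl ring of the benzyl(ethyl)amino group turns out to be a place where a single added atom moves the read-out: bromo in place of hydrogen on an aromatic carbon gives a number 13.3 percentage points higher from compound 2 to compound 3 (beyond the scatter), a modest step but the first measured on this ring, which so far had been seen only unsubstituted. Set against the bis(2-(dimethylamino)ethyl)amino group, the (3-bromobenzyl)(ethyl)amino group gives a number 76.4 percentage points higher from compound 1 to compound 3 (beyond the scatter), so the large gap opened by the benzyl(ethyl)amino group widens further with this one substituent. Nothing at hand accounts for the gain from bromo, and the read-out at a single concentration gives its size and not a potency.

The compounds shown do not tell whether the gain is particular to bromine or also holds for chloro, fluoro, methyl or methoxy at the same place, nor whether bromo elsewhere on the ring behaves alike. Also open, going by these compounds, is how an amine or a carboxylic acid on the benzyl ring would read, and whether a longer chain in place of the ethyl group keeps the value of compound 3.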